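The source may report more compounds than this note shows. Statements on the series, on what has been measured and on what is new or still open speak of the compounds shown alone.

Compound 3 `CCC(C)(C)Cc1c[nH]c(CCc2ccc(-c3cnsc3)cc2)n1` carries a 1,2-thiazol-4-yl group on the shared core, and in an in vitro assay on CHO cells for displacement of a labelled ligand from Bombesin receptor subtype-3 (Homo sapiens), read by scintillation counting, with a stated time of 2 h (a lower number here means a stronger inhibitor, a higher number a weaker inhibitor), compound 3 gives 10 nM. Among the three measured compounds that number stands second highest. Compound 1 `CCC(C)(C)Cc1c[nH]c(CCc2ccc(-c3cccc(C)n3)cc2)n1` gives 6.3 nM in this assay, and compound 2 `CCC(C)(C)Cc1c[nH]c(CCc2ccc(-c3cnccn3)cc2)n1` gives 51 nM. The measured steps are a 1.6-fold higher number from compound 1 to compound 3 (0.20 log units; within the scatter), a 5.1-fold lower number from compound 2 to compound 3 (0.71 log units; beyond the scatter) and an 8.1-fold higher number from compound 1 to compound 2 (0.91 log units; beyond the scatter); all of them exchange one aromatic heterocycle for another at the same place. Compound 4 `CCC(C)(C)Cc1c[nH]c(CCc2ccc(N3CCCCC3)cc2)n1` differs from compound 3 by piperidin-1-yl in place of 1,2-thiazol-4-yl on an aromatic carbon. Among the compounds with values here, no measured step puts a non-aromatic ring at this position, so the steps that bear on the change only show how widely that position has moved the number so far, namely a 5.1-fold lower number from compound 2 to compound 3 (0.71 log units; beyond the scatter) at most. A step of modest size in this assay is therefore expected, more likely toward a higher number than a lower one. Compound 4 is estimated at 18 nM, in the range 5 nM to 70 nM, which means an expected step of a 1.8-fold higher number from compound 3 to compound 4 (0.26 log units; within the scatter).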

Compound 4, half-maximal inhibitory concentration: 28 nM
Compound 4: middle estimate off by 1.6-fold (0.19 log units), on the low side; the measured number falls inside the stated range.
By their numbers in this assay, from the lowest: compounds 1 and 3 (each within the scatter of the next); then compounds 4 and 2 (each within the scatter of the next).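

Compound 4 is the only compound shown with a non-aromatic ring on this aromatic carbon, and in this assay the piperidin-1-yl group gives a step of modest size from each of the two compounds with the lowest numbers (a 2.8-fold higher number from compound 3 to compound 4 (0.45 log units; beyond the scatter); a 4.4-fold higher number from compound 1 to compound 4 (0.65 log units; beyond the scatter)). The step from the pyrazin-2-yl group, by contrast, stays within the scatter (a 1.8-fold lower number from compound 2 to compound 4 (0.26 log units; within the scatter)). An aromatic ring at this position is therefore not needed for a number in the range of compound 2, though compound 4 does not match compound 1 or compound 3. Nothing shown accounts for these steps. The compounds shown leave open how a morpholin-4-yl or pyrrolidin-1-yl ring would compare with piperidin-1-yl here, and whether an open-chain amine such as dimethylamino would behave like the ring.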